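Acyl change from compound 3 to compound 4

This account rests on a few compounds, and the source may have more. Where it says the series, first, only, none or still open, it means among the compounds named here.

Measured so far in a functional assay on COR-L23 cells (Homo sapiens) for antiproliferative activity, read by CellTiter-Glo, with a stated time of 72 h (on this read-out lower numbers stand for stronger inhibition and higher numbers for weaker inhibition), on the series:
- compound 1 `C[C@@H](c1ccc(NC(=O)N2CC(c3cncc(N)c3)C2)cc1)N1Cc2ccccc2C1=O` gives 130 nM
- compound 2 `C[C@H](NC(=O)C1CCOCC1)c1ccc(NC(=O)N2CC(c3cncc(N)c3)C2)cc1` gives 970 nM
- compound 3 `C[C@H](NC(=O)[C@@H]1CCCN1C)c1ccc(NC(=O)N2CC(c3cncc(N)c3)C2)cc1` gives 200 nM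

Two gaps place the starting amide: a 1.5-fold higher number from compound 1 to compound 3 (0.19 log units; within the scatter) on one side and a 4.9-fold lower number from compound 2 to compound 3 (0.69 log units; beyond the scatter) on the other. Compound 3 therefore cannot be told apart from compound 1, while its number is clearly lower than that of compound 2.

The change to compound 4 `CCC(=O)N[C@@H](C)c1ccc(NC(=O)N2CC(c3cncc(N)c3)C2)cc1` is ethyl in place of 1-methylpyrrolidin-2-yl on a carbonyl carbon, counted in full as ethyl in place of 1-methylpyrrolidin-2-yl on a carbonyl carbon for this pair.

The most direct evidence is the modest step of a 4.9-fold lower number from compound 2 to compound 3 (0.69 log units; beyond the scatter) at that same carbonyl carbon, where 1-methylpyrrolidin-2-yl took the place of oxan-4-yl. Compound 4 also lacks 1-methylpyrrolidin-2-yl, which points to some loss of that gain. A less direct guide is a 7.5-fold higher number from compound 1 to compound 2 (0.87 log units; beyond the scatter) for a larger group change. Among the measured compounds shown here, no measured compound carries ethyl, so the size remains uncertain.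

A modest move to a higher number is therefore expected in this assay for this change. The estimated step is a 2.5-fold higher number from compound 3 to compound 4 (0.40 log units; beyond the scatter) on this read-out. For compound 4 the estimate is 500 nM as the middle, with an expected range from 180 nM to 1400 nM for repeat measurements.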

Compound 4, half-maximal inhibitory concentration in the COR-L23 assay: 1580 nM
Estimate against measurement, compound 4: 3.2-fold (0.50 log units) below, outside the stated range (above it).
By their numbers in the COR-L23 assay, from the lowest: compounds 1 and 3 (each within the scatter of the next); then compounds 2 and 4 (each within the scatter of the next).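

In the COR-L23 assay, ethyl does not hold the level reached with 1-methylpyrrolidin-2-yl on this carbonyl carbon: a 7.9-fold higher number from compound 3 to compound 4 (0.90 log units; beyond the scatter), while a 1.6-fold higher number from compound 2 to compound 4 (0.21 log units; within the scatter) leaves ethyl and oxan-4-yl not separable, so the gain seen earlier is not a partial one that survives in a small acyl group. The widest gap among these compounds is a 12-fold higher number from compound 1 to compound 4 (1.08 log units; beyond the scatter), for the whole group on the saturated chain carbon, and of the three amides only the 1-methylpyrrolidin-2-yl amide stays within the scatter of compound 1. In a physicochemical assay for solubility, read by LC-MS, in phosphate buffer, with a stated time of 24 h, at pH 6.8 (on this read-out lower numbers stand for lower solubility and higher numbers for higher solubility), compound 3 gives 820000 nM and compound 4 gives 230000 nM. The same exchange also registers in the physicochemical assay, so the loss in the cell read-out comes with no gain in solubility: the measured solubility of compound 3, 820000 nM, and of compound 4, 230000 nM, a 3.6-fold lower number (0.55 log units; beyond the scatter)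

With only ethyl, oxan-4-yl and 1-methylpyrrolidin-2-yl on this carbonyl carbon, the compounds shown do not separate the contribution of the ring from that of its nitrogen or of the methyl on that nitrogen. From the compounds shown here alone, a pyrrolidin-2-yl group without the methyl, or an open-chain dimethylaminomethyl group at the same place, would bear on that question, and the opposite stereocentre in the 1-methylpyrrolidin-2-yl group also remains open.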